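Replacing the Chain Sulfonamide with a Nitrile

This account rests on a few compounds, and the source may have more. Where it says the series, first, only, none or still open, it means among the compounds named here.

Compound 1 `CN(c1ccccc1CCCn1nnnc1[C@@H](COCc1ccccc1)NC(=O)C(C)(C)N)S(C)(=O)=O`: 14 nM
Compound 2 `CC(C)(N)C(=O)N[C@H](COCc1ccccc1)c1nnnn1CCCCCNS(C)(=O)=O`: 75 nM

Within the data shown here, compound 2 stands at the higher of the two numbers in a functional assay on H4 cells for agonist activity at growth hormone secretagogue receptor type 1 (Homo sapiens), read by FLIPR; a lower number here means that less compound is needed, a higher number that more compound is needed for the effect; the only measured step is a 5.4-fold higher number from compound 1 to compound 2 (0.73 log units; beyond the scatter). Compound 3 `CC(C)(N)C(=O)N[C@H](COCc1ccccc1)c1nnnn1CCCCC#N` differs from compound 2 by cyano in place of (methanesulfonamido)methyl on a saturated chain carbon, four bonds along the chain from an aromatic nitrogen. Among the measured compounds shown here, no measured step removes the sulfonamide from this chain end, so the single step bears on it only loosely, and that step was modest. The shift is therefore estimated as a modest rise, a 2.0-fold higher number from compound 2 to compound 3 (0.30 log units; within the scatter). Compound 3 is expected near 150 nM, in a range from 40 nM to 600 nM.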

Compound 3, half-maximal effective concentration: 35 nM
Beside the measured number, compound 3's estimate is 4.3-fold (0.63 log units) above it, outside the stated range (below it).
By their numbers in this assay, from the lowest: compound 1; then compound 3; then compound 2.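

In this assay the sulfonamide at this chain end proves dispensable: cyano in place of (methanesulfonamido)methyl gives a 2.1-fold lower number from compound 2 to compound 3 (0.33 log units; beyond the scatter) on a smaller group with no hydrogen-bond donor. The aryl sulfonamide chain still does better, with a 2.5-fold higher number from compound 1 to compound 3 (0.40 log units; beyond the scatter) for cyanomethyl in its place. Nothing available here accounts for either step.

From the compounds shown here alone, it remains open whether a carboxylic acid or an amine at this chain end would match the nitrile. Going by these compounds, it is also open how a longer chain ending in the nitrile would compare.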